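The source may report more compounds than this note shows. Statements on the series, on what has been measured and on what is new or still open speak of the compounds shown alone.

In a functional assay on HCT-116 cells (Homo sapiens) for cytotoxicity, read by MTT assay, with a stated time of 48 h, in the presence of a further agent that is not named here (on this read-out lower numbers stand for an effect already at smaller amounts and higher numbers for an effect only at larger amounts of compound), compound 1 (`CCCc1cc(NNC(=O)Nc2cc(Cl)nc(Cl)c2)nc2c1c(C)nn2C`) gives 72200 nM and lies within the scatter of the other two measured compounds. Compound 2 (`Cc1nn(C)c2nc(NNC(=O)Nc3cc(Cl)nc(Cl)c3)cc(-c3ccco3)c12`) gives 69200 nM there, and compound 3 (`Cc1nn(C)c2nc(NNC(=O)Nc3cc(Cl)nc(Cl)c3)cc(-c3ccccc3)c12`) gives 80000 nM there, so the three values form a single level. Compound 4 (`CCCc1cc(NNC(=O)Nc2cc(Cl)nc(Cl)c2)nc2c1c(C(F)(F)F)nn2C`) keeps the propyl of compound 1 but carries trifluoromethyl in place of methyl on an aromatic carbon. Among the compounds with values here, no measured step touches that place. The available steps concern the propyl instead: furan-2-yl gives a 1.0-fold lower number from compound 1 to compound 2 (0.02 log units; within the scatter) and phenyl gives a 1.1-fold higher number from compound 1 to compound 3 (0.04 log units; within the scatter) while the exchange of those two groups gives a 1.2-fold higher number from compound 2 to compound 3 (0.06 log units; within the scatter) and all remain within the scatter. These steps show a flat response to changes elsewhere in the molecule, but they offer only indirect guidance on the new group. The expected step is a 1.1-fold lower number from compound 1 to compound 4 (0.05 log units; within the scatter) and thus none beyond the scatter. Compound 4 is estimated at 65000 nM with an expected range from 28000 nM to 130000 nM as the likely span.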

Compound 4, half-maximal effective concentration: 38200 nM
For compound 4 the middle estimate is 1.7-fold (0.23 log units) above the measured one; measured number inside the range.
By their numbers in this assay, from the lowest: compounds 4, 2, 1 and 3 (each within the scatter of the next, the first and the last beyond it).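

This is the first change shown at the aromatic carbon of the five-membered ring, next to the ring nitrogen, whereas the earlier steps all concerned the propyl. In this assay, trifluoromethyl in place of methyl gives a 1.9-fold lower number from compound 1 to compound 4 (0.28 log units; within the scatter), a step greater in size than each of the three earlier ones, yet still not separable from repeat-measurement noise, so this place, too, has not been shown to change the read-out. Nothing available here explains the size of this step.

The compounds shown leave open whether an amine or a longer chain in place of the methyl would move the number beyond the scatter. They also leave open whether trifluoromethyl would give a similar step alongside furan-2-yl or phenyl instead of propyl.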